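Shortening the alkyl chain on the acetylated series

A few compounds are considered here, and "the series" means these few. Any claim that something is new, unique, unknown or untested is made for them only; others in the source may bear on it.

Compound 1 `CCCCc1ccc(-c2cc(-c3cn([C@H]4C[C@H](OC(C)=O)[C@@H](COC(C)=O)O4)c(=O)[nH]c3=O)on2)cc1` is the diacetylated member of the set. In a functional assay on NUGC-3 cells (Homo sapiens) for cytotoxicity, read by sulforhodamine B assay, tested at 10 uM (a higher number here means more inhibition at the concentration tested (going by the name of the read-out), a lower number less inhibition), compound 1 gives 39.8%, the lowest of the three numbers recorded. Compound 2 `CCCCCCCCc1cc(-c2cn([C@H]3C[C@H](O)[C@@H](CO)O3)c(=O)[nH]c2=O)on1` carries a longer chain directly on its five-membered heteroaromatic ring and free hydroxyls on the sugar; in this assay compound 2 gives 76.4%, a number beyond the scatter above compound 1. Compound 3 `O=c1[nH]c(=O)n([C@H]2C[C@H](O)[C@@H](CO)O2)cc1-c1cn(Cc2ccccc2)nn1`, also with free hydroxyls, gives 95.6% in this assay, further still above compound 1. Compounds 2 and 3 differ from compound 1 in several places at once, so no single-point step can be read from them.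

Compound 4 `CCc1ccc(-c2cc(-c3cn([C@H]4C[C@H](OC(C)=O)[C@@H](COC(C)=O)O4)c(=O)[nH]c3=O)on2)cc1` is the next member, derived from compound 1 by the change (hydrogen in place of ethyl on a saturated chain carbon, two bonds along the chain from an aromatic carbon). Going by the values given here, no measured pair shows what a change of this kind does in this assay, so the expectation rests on compound 1 alone. The step from compound 1 to compound 4 is expected to be small, a number 3.8 percentage points lower from compound 1 to compound 4 (within the scatter), with no direction confidently resolved beyond the scatter. In this assay compound 4 is therefore expected to give about 36%, with a plausible range from 15% to 60%.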

Compound 4, a percentage reported as inhibition, at one concentration (the size of the read-out at that concentration, not a potency): 72.6%
Estimate against measurement, compound 4: 36.6 percentage points below; measured number above the stated range.
By their numbers in this assay, from the lowest: compound 1; then compounds 4 and 2 (each within the scatter of the next); then compound 3.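

The pair gives the series its first single-point reading: cutting 4-butylphenyl to 4-ethylphenyl, with the diacetylated remainder of the structure unchanged, gives a number 32.8 percentage points higher from compound 1 to compound 4 (beyond the scatter) in this assay. This chain position is therefore not a silent one, since losing an ethyl in favour of hydrogen, with no ring, hydrogen-bond donor or hydrogen-bond acceptor leaving or entering, is enough for a large step in this read-out. Nothing measured on these compounds bears on what lies behind that step.

Going by these compounds alone, with only two chain lengths on this phenyl ring, one step cannot show whether the number follows chain length steadily or changes abruptly somewhere between butyl and ethyl, and a methyl, a hexyl chain, or a chain ending in an amine or a carboxylic acid would be needed to settle how far the number moves with changes at this position. Within the data shown here, whether the same change holds with free hydroxyls on the sugar in place of the acetates also stays open, as no single-point pair links the acetylated compounds to compound 2 or compound 3.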